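This account rests on a few compounds, and the source may have more. Where it says the series, first, only, none or still open, it means among the compounds named here.

Series notes. Among the measured compounds shown here, in a functional assay on SW-620 cells (Homo sapiens) for cytotoxicity, read by MTT assay, with a stated time of 72 h (a lower number here means a stronger inhibitor, a higher number a weaker inhibitor), compound 3 `Cc1ccc(/C=C2\S/C(=N\c3nc(-c4ccc(Cl)cc4)cs3)NC2=O)cc1` gives 890 nM, and this is the only plain number in hand across the three measured entries. Compound 1 `COc1ccc(-c2cc(/N=C3/NC(=O)CS3)cs2)cc1` returns only a limit in this assay, > 50000 nM, and so sits at the limit of > 50000 nM in this assay, at which 1 of the 3 values shown sits. For compound 2 `CN(C)c1ccc(N2C(=O)CS/C2=N\c2csc(-c3ccc(Cl)cc3)c2)cc1` this assay holds "not determined" (no result reported). Compound 3 therefore stands alone as the one measured point against which a new entry can be set, with compound 1 at a limit and compound 2 without a result.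

Compound 4 `O=C1N/C(=N/c2nc(-c3ccc(Cl)cc3)cs2)S/C1=C\c1ccc(F)cc1` differs from compound 3 by fluoro in place of methyl on an aromatic carbon, para to a large group. For the measured compounds named here, no measured pair shares that change, so nothing in hand reports its size or direction. The step of a 1.2-fold higher number from compound 3 to compound 4 (0.09 log units; within the scatter) is expected to stay within the scatter of repeated measurements, with no direction favoured. Compound 4 is accordingly estimated at 1100 nM in this assay, with an expected range from 400 nM to 3500 nM.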

Compound 4, half-maximal inhibitory concentration: > 50000 nM
Compound 4 was reported as a limit; the forecaster's own chance of this, stated with the estimate: 5%; at least 45-fold (1.65 log units) between middle value and limit.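

In this assay, among the compounds shown here, the change from 4-methylphenyl to 4-fluorophenyl gives the first step between compounds that differ in one place: an at least 56-fold higher number from compound 3 to compound 4 (1.74 log units; beyond the scatter). On this aromatic carbon, para to a large group, exchanging methyl for fluoro is therefore far from neutral, although each group counts as one heavy atom. Compound 4 stands at a limit of the assay and not at a number, so the step has a lower bound but no fixed size: the limit of > 50000 nM in this assay, at which 2 of the 4 values shown sit.

A single pair cannot show whether this steep change belongs to fluoro itself or would follow any replacement of methyl here. On these data alone, an ethyl group, a hydroxyl or an amine at the same place would separate those readings, and how the change behaves on another core also remains open.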